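The compounds below may be only part of what the source reports. "The series", "measured", "known", "first", "only" and "open" are said of these compounds alone.

Measured compounds:
compound 1 `CN(C)CCCNc1nc(-c2ccc(NC(=O)Nc3ccc(Cl)cc3Cl)cc2)nc2c(Cl)c(Cl)sc12`, 2560 nM
compound 2 `CCN(CC)CCNc1nc(-c2ccc(NC(=O)Nc3ccc(Cl)cc3)cc2)nc2c(Cl)c(Cl)sc12`, 890 nM

In a functional assay on MKN-45 cells (Homo sapiens) for cytotoxicity, read by MTT assay, with a stated time of 72 h (on this read-out lower numbers stand for stronger inhibition and higher numbers for weaker inhibition), compound 2 gives the lowest of the two numbers, and compound 1 gives a number beyond the scatter above it. Compound 3 `CCN(CC)CCNc1nc(-c2ccc(NC(=O)Nc3ccc(Cl)cc3Cl)cc2)nc2c(Cl)c(Cl)sc12` is not yet measured; it differs from compound 2 by chloro in place of hydrogen on an aromatic carbon. Among the measured compounds shown here, no measured pair shows this single change, so its size is not known from these data. Compound 3 is expected to move by a 1.5-fold higher number from compound 2 to compound 3 (0.16 log units; within the scatter), a small step toward a weaker number, and its value is estimated at 1300 nM, within 500 nM to 3500 nM.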

Compound 3, half-maximal inhibitory concentration: 1770 nM
Estimate against measurement, compound 3: 1.4-fold (0.13 log units) below, and the stated range covers the measured number.
By their numbers in this assay, from the lowest: compounds 2, 3 and 1 (each within the scatter of the next, the first and the last beyond it).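

In this assay the change from 4-chlorophenyl to 2,4-dichlorophenyl gives a 2.0-fold higher number from compound 2 to compound 3 (0.30 log units; within the scatter) and so shows that a chloro on this aromatic carbon, ortho to a large group, leaves no change that can be told from scatter. With the 2,4-dichlorophenyl kept, diethylamino in place of (dimethylamino)methyl gives a 1.4-fold lower number from compound 1 to compound 3 (0.16 log units; within the scatter) and so does not separate these two side chains either. Nothing measured here offers an explanation for either step.

Going by these compounds, whether a fluoro, a methoxy or a trifluoromethyl on this same carbon would read differently stays open. So does whether a side chain ending in a morpholine or a piperazine would move the number beyond the scatter.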